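The source may report more compounds than this note shows. Statements on the series, on what has been measured and on what is new or still open speak of the compounds shown alone.

The series shares one core, a tryptamine-type fragment bearing a triazole, linked through a three-carbon chain to a piperidine whose fourth carbon carries a varying aromatic group. Compound 1 `c1ccc(CC2CCN(CCCc3c[nH]c4ccc(-n5cnnc5)cc34)CC2)cc1` carries a plain benzyl group there, and in an assay on CHO cells for displacement of a labelled ligand from 5-hydroxytryptamine receptor 1B (Homo sapiens) (on this read-out lower numbers stand for stronger inhibition and higher numbers for weaker inhibition), compound 1 gives 19 nM. Compound 2 `FC1(Cc2ccccc2C(F)(F)F)CCN(CCCc2c[nH]c3ccc(-n4cnnc4)cc23)CC1` carries a fluorine on that ring carbon together with a 2-(trifluoromethyl)benzyl group, and in this assay compound 2 gives 14 nM. Among the measured compounds shown here, of the two numbers measured so far, compound 2 has the lower one, but compound 1 lies within the scatter of it, so the two compounds cannot be separated on these data.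

Compound 3 `Fc1cccc(CCC2(F)CCN(CCCc3c[nH]c4ccc(-n5cnnc5)cc34)CC2)c1` keeps the fluorine on the ring carbon and differs from compound 2 as follows: 3-fluorobenzyl in place of 2-(trifluoromethyl)phenyl on a saturated chain carbon bound to a saturated ring carbon. For the measured compounds named here, no measured pair in this set shows the effect of such a change, so the expectation rests on the closeness of compound 1 and compound 2 alone. The step from compound 2 to compound 3 in this assay is expected to be a 1.6-fold higher number from compound 2 to compound 3 (0.20 log units; within the scatter), that is, nothing beyond the scatter. Compound 3 is therefore estimated to give 22 nM in this assay, within a range from 7 nM to 70 nM.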

Compound 3, half-maximal inhibitory concentration: 22 nM
For compound 3 middle estimate and measured number coincide at the digits printed, within the range that was stated.
By their numbers in this assay, from the lowest: compounds 2, 1 and 3 (each within the scatter of the next).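

In this assay, exchanging the 2-(trifluoromethyl)benzyl group of compound 2 for the 2-(3-fluorophenyl)ethyl group of compound 3 gives a 1.6-fold higher number from compound 2 to compound 3 (0.20 log units; within the scatter), so this pair cannot be told apart on this read-out. The place on a saturated chain carbon bound to a saturated ring carbon thus tolerates this change of group with the ring fluorine kept, although the step joins two alterations, a different substituent on the aromatic ring and an ethyl chain in place of a benzyl one, and a single pair cannot separate their contributions. No independent measurement accompanies this result to explain why the number holds across the change.

Still open, from the compounds shown here alone, is whether this tolerance extends to groups of another kind at the same place, such as an amine or a carboxylic acid on the aromatic ring, or a longer chain such as 3-phenylpropyl. Also open is what the fluorine on the ring carbon contributes, since the compounds shown offer no pair that differs in that atom alone, for instance against a hydroxyl group there.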